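Methoxy in Place of Fluoro: Estimating Compound 4

The source may report more compounds than this note shows. Statements on the series, on what has been measured and on what is new or still open speak of the compounds shown alone.

Compound 1 `COc1ccc(S(C)(=O)=O)c(NCC2=NCCN2)c1`: 102%
Compound 2 `CSc1ccc(C)cc1NCC1=NCCN1`: 101%
Compound 3 `CSc1ccc(F)cc1NCC1=NCCN1`: 90%

All three were measured in a functional assay for agonist activity at Alpha-1A adrenergic receptor (Homo sapiens); a lower number here means a smaller maximal response, a higher number a larger maximal response. Compound 3 stands lowest of the three numbers, with compound 2 nearest and compound 1 furthest above it. Among the measured compounds shown here, the single measured step, a number 11 percentage points lower from compound 2 to compound 3 (beyond the scatter), came with fluoro in place of methyl on an aromatic carbon.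

Compound 4 `COc1ccc(SC)c(NCC2=NCCN2)c1` has not yet been measured. Its difference from compound 3: methoxy in place of fluoro on an aromatic carbon. For the measured compounds named here, no measured step covers methoxy against fluoro directly; the one measured step only shows that fluoro at this spot went with a modestly lower number, and compound 1, which carries methoxy, sits high. Compound 4 is therefore expected to show a number 10 percentage points higher from compound 3 to compound 4 (within the scatter), a modest rise. Compound 4 is estimated at 100%, within 88% to 108%.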

Compound 4, largest response reached (reported as maximum), in percent of the reference or control that the assay uses: 101%
Beside the measured number, compound 4's estimate is 1 percentage points below it; the range from low to high includes it.
By their numbers in this assay, from the lowest: compound 3; then compounds 2, 4 and 1 (each within the scatter of the next).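

In this assay, the aromatic carbon para to the methylsulfanyl group now has a direct comparison of methoxy in place of fluoro, which gives a number 11 percentage points higher from compound 3 to compound 4 (beyond the scatter) and shows that the lower response goes with fluoro among these groups. Methoxy in place of methyl gives no change at the digits printed from compound 2 to compound 4 (within the scatter) so these two groups cannot be told apart here. Methylsulfanyl in place of methylsulfonyl gives a number 1 percentage points lower from compound 1 to compound 4 (within the scatter) so this second site also shows no difference within the scatter.

Going by these compounds, whether an amine or a carboxylic acid at the same carbon would keep the response stays open. No measurement shown gives a reason for any of these steps.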